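The source may report more compounds than this note shows. Statements on the series, on what has been measured and on what is new or still open speak of the compounds shown alone.

Of the compounds shown here, two with a shared core have been measured in a functional assay on HEK293 cells for agonist activity at G-protein coupled receptor 39 (Homo sapiens), read by scintillation proximity assay and inositol phosphate accumulation, with a stated time of 75 min, in the presence of a further agent that is not named here; on this read-out higher numbers stand for an effect only at larger amounts of compound and lower numbers for an effect already at smaller amounts. Compound 1 `Cc1nn(-c2ncnc3nc[nH]c23)c2c1C(C(=O)NCc1ccc(F)cc1)CC(=O)N2` gives 4 nM in this assay. Compound 2 `Cc1cc(C)n(CCOC2CC(=O)Nc3c2c(C)nn3-c2ncnc3nc[nH]c23)n1` gives 16 nM in this assay, the higher of the two numbers, and its gap to compound 1 lies beyond the scatter of repeated measurements.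

Compound 3 `Cc1nn(-c2ncnc3nc[nH]c23)c2c1C(C(=O)NCc1ccccc1)CC(=O)N2` has not yet been measured. It differs from compound 2 in one place: a group of 10 heavy atoms (8 carbon, 1 nitrogen, 1 oxygen; one six-membered aromatic ring of carbon only) in place of a group of 10 heavy atoms (7 carbon, 2 nitrogen, 1 oxygen; one five-membered aromatic ring with 2 hetero atoms), on a saturated ring carbon. Going by the values given here, in its structure compound 3 stands closer to compound 1 than to compound 2, since both carry an amide-linked aromatic group on that saturated ring carbon; no step between compound 1 and compound 3 is given, so only their structures can be compared.

On this basis the step expected from compound 2 to compound 3 in this assay is a 2.7-fold lower number from compound 2 to compound 3 (0.43 log units; beyond the scatter), a move toward lower numbers that goes beyond the scatter. Compound 3 is estimated at 6 nM in this assay, with a range from 2 nM to 20 nM.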

Compound 3, half-maximal effective concentration: 5 nM
Compound 3: the middle estimate sits 1.2-fold (0.08 log units) above what was measured; low and high end bracket the measured number.
By their numbers in this assay, from the lowest: compounds 1 and 3 (each within the scatter of the next); then compound 2.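

In this assay, the benzylcarbamoyl group on the saturated ring carbon, in place of the group carrying the five-membered aromatic ring, gives a 3.2-fold lower number from compound 2 to compound 3 (0.51 log units; beyond the scatter), so a change at this position can move the number beyond the scatter. Hydrogen in place of fluoro on an aromatic carbon gives a 1.3-fold higher number from compound 1 to compound 3 (0.10 log units; within the scatter), which lies within the scatter, so the fluoro makes no readable difference in this assay for this pair. Nothing at hand explains either step.

As far as these compounds go, it remains open how a chloro or methoxy group on that aromatic ring would read, and whether a longer chain between the amide nitrogen and the ring would hold the number. Also open, from the compounds shown here alone, is how an amine or a carboxylic acid on the saturated ring carbon would compare with the benzylcarbamoyl group.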